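Swapping the chlorothiophene amide in a weak HSP60 inhibitor

A few compounds are considered here, and "the series" means these few. Any claim that something is new, unique, unknown or untested is made for them only; others in the source may bear on it.

Measured compounds:
compound 1, `COc1ccc(S(=O)(=O)Nc2ccc3oc(-c4ccc(NC(=O)c5ccc(Cl)s5)cc4)nc3c2)cc1`, 61000 nM
compound 2, `O=C(Nc1ccc(Sc2nc3ccccc3s2)c(Cl)c1)c1cccc(Br)c1O`, 7700 nM

In an assay on mitochondria for inhibition of HSP60/HSP10 (Homo sapiens) (a lower number here means a stronger inhibitor, a higher number a weaker inhibitor), compound 1 gives 61000 nM, the higher of the two numbers. Compound 2 gives 7700 nM in this assay, a lower number, and the gap between them lies beyond the usual scatter; the two structures differ in many places, so nothing is drawn from that pair about any single change.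

Compound 3, `COc1ccc(S(=O)(=O)Nc2ccc3oc(-c4ccc(NC(=O)C5CCN(C(C)=O)CC5)cc4)nc3c2)cc1`, has not been measured in this assay. It differs from compound 1 in one place: 1-acetylpiperidin-4-yl in place of 5-chlorothiophen-2-yl on a carbonyl carbon. Among the measured compounds shown here, no measured pair shows the effect of this exchange, so the direction of the step is open. For the measured compounds named here, compound 1 is already a weak inhibitor, and the exchange removes the only aromatic group on that carbonyl; a step toward a weaker inhibitor is judged somewhat more likely than one toward a stronger one, but a change within the scatter is also plausible. Compound 3 is therefore expected at about 100000 nM, between 30000 nM and 300000 nM, which means an expected step of a 1.6-fold higher number from compound 1 to compound 3 (0.21 log units; within the scatter).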

Compound 3, half-maximal inhibitory concentration: 24000 nM
Beside the measured number, compound 3's estimate is 4.2-fold (0.62 log units) above it; measured number outside the range, below it.
By their numbers in this assay, from the lowest: compound 2; then compound 3; then compound 1.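

In this assay, replacing 5-chlorothiophen-2-yl with 1-acetylpiperidin-4-yl on a carbonyl carbon gives a 2.5-fold lower number from compound 1 to compound 3 (0.41 log units; beyond the scatter), so this position accepts a six-membered non-aromatic ring in place of a five-membered aromatic one without any loss of inhibition. The chlorothiophene is therefore not required for the inhibition seen in this series, although compound 3, at 24000 nM, is still a weak inhibitor and the step is modest. Nothing available bears on the reason for this gain.

This single exchange changes the ring, the chlorine and the acetyl group together, so the compounds shown cannot say which of them accounts for the step, and a piperidin-4-yl with a free amine, a plain thiophen-2-yl or a cyclohexyl group would be needed to separate these parts. They also leave open how far this position can be extended, for instance with a longer chain ending in a carboxylic acid, and whether any group here can bring a much larger step than the one seen.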